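Series notes: acid-to-amide step at the chain terminus

A few compounds are considered here, and "the series" means these few. Any claim that something is new, unique, unknown or untested is made for them only; others in the source may bear on it.

Measured so far, in a functional assay on CHO cells for agonist activity at Free fatty acid receptor 1 (Homo sapiens); a higher number here means that more compound is needed for the effect, a lower number that less compound is needed:
- compound 1 `O=C(O)CCCc1ccc(NCc2cccc(Oc3ccccc3)c2)cc1`: 1120 nM
- compound 2 `CC(Cc1ccc(NCc2cccc(Oc3ccccc3)c2)cc1)C(=O)O`: 100 nM
- compound 3 `Cc1nc(-c2ccc(C(F)(F)F)cc2)sc1CNc1ccc(CC(C)C(=O)O)cc1`: 355 nM

Compound 2 has the lowest number of the three; compound 3 stands nearest to it and compound 1 furthest. Among the compounds with values here, the one step between two measured compounds that differ in one place, an 11-fold lower number from compound 1 to compound 2 (1.05 log units; beyond the scatter), shows that shifting the carboxyl along the chain alone moves the number a long way.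

Compound 4 `CC(C)NC(=O)CCc1ccc(NCc2cccc(Oc3ccccc3)c2)cc1` is not yet measured. It differs from compound 2 by (isopropylcarbamoyl)methyl in place of 1-carboxyethyl on a saturated chain carbon bound to an aromatic carbon. Within the data shown here, no measured pair covers a change of this kind: every measured compound keeps a carboxylic acid, and compound 4 has none. The measured step from compound 1 to compound 2 bears on it only indirectly, in that the position of the acid already controlled a large part of the response in this assay. A change that removes the acid and replaces it with an amide is therefore expected to give a large step upward, a 120-fold higher number from compound 2 to compound 4 (2.08 log units; beyond the scatter), and it may also run out of the range of this assay. The estimate for compound 4 is 12000 nM, within 2500 nM to 60000 nM.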

Compound 4, half-maximal effective concentration: 39.8 nM
Estimate against measurement, compound 4: 300-fold (2.48 log units) above; measured number outside the range, below it.
By their numbers in this assay, from the lowest: compound 4; then compound 2; then compound 3; then compound 1.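

Working notes, acid-to-amide step: in this assay, a carboxylic acid is not required at this position, since (isopropylcarbamoyl)methyl in place of 1-carboxyethyl gives a 2.5-fold lower number from compound 2 to compound 4 (0.40 log units; beyond the scatter) on the shared core. The change from the other acid on that core is larger, with a 28-fold lower number from compound 1 to compound 4 (1.45 log units; beyond the scatter) leaving compound 4 with the lowest number among the three compounds on this core. No supporting data are available to explain why the amide performs this way.

On these data alone, it remains open whether this result belongs to the amide itself or to its isopropyl group; a primary amide, a tert-butyl amide or a methyl ester at the same chain end would help separate the two. Also open, as far as these compounds go, is whether the isopropyl amide would give a similar step on the core of compound 3.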